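Aryl replacement on the hydrazone carbon: compound 4

The source may hold more compounds than are shown below. What is called first, only, known or untested is meant among the compounds shown, and "the series" means these compounds.

Compound 2 `CN(C)CCn1cnnc1-c1cc(Oc2ccc(NC(=O)N/N=C/c3cccc(Cl)c3Cl)cc2F)ccn1` gives 51 nM in a functional assay on MKN-45 cells (Homo sapiens) for cytotoxicity, read by MTT assay, with a stated time of 72 h (on this read-out higher numbers stand for weaker inhibition and lower numbers for stronger inhibition), the lowest of the three numbers in hand. Compound 1 `CN(C)CCn1cnnc1-c1cc(Oc2ccc(NC(=O)N/N=C/c3cccc(O)c3)cc2F)ccn1` gives 1370 nM and compound 3 `CN(C)CCn1cnnc1-c1cc(Oc2ccc(NC(=O)N/N=C/c3c(O)ccc4ccccc34)cc2F)ccn1` gives 2020 nM. The steps of a 27-fold lower number from compound 1 to compound 2 (1.43 log units; beyond the scatter) and a 40-fold higher number from compound 2 to compound 3 (1.60 log units; beyond the scatter) are both large; by contrast a 1.5-fold higher number from compound 1 to compound 3 (0.17 log units; within the scatter) is within the scatter.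

Compound 4 `COc1ccc(/C=N/NC(=O)Nc2ccc(Oc3ccnc(-c4nncn4CCN(C)C)c3)c(F)c2)c(OC)c1OC` differs from compound 2 by 2,3,4-trimethoxyphenyl in place of 2,3-dichlorophenyl on a carbon with a double bond to nitrogen. Both oxygen-bearing aryl groups measured so far on this carbon give far higher numbers than the 2,3-dichlorophenyl of compound 2. A large rise in this assay is therefore expected for compound 4 because a 40-fold higher number from compound 2 to compound 3 (1.60 log units; beyond the scatter) and a 27-fold lower number from compound 1 to compound 2 (1.43 log units; beyond the scatter) both show that leaving the 2,3-dichlorophenyl costs heavily. Within the data shown here, no measured step tells whether a methoxy-bearing ring behaves like a hydroxyl-bearing one, so the range is kept wide.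

Compound 4 is estimated at 1000 nM, within 300 nM to 4000 nM, which means an expected step of a 20-fold higher number from compound 2 to compound 4 (1.29 log units; beyond the scatter).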

Compound 4, half-maximal inhibitory concentration: 2020 nM
Compound 4: middle estimate off by 2.0-fold (0.31 log units), on the low side; measured number inside the range.
By their numbers in this assay, from the lowest: compound 2; then compounds 1, 3 and 4 (each within the scatter of the next).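

In this assay the 2,3,4-trimethoxyphenyl on the carbon with a double bond to nitrogen gives a 40-fold higher number from compound 2 to compound 4 (1.60 log units; beyond the scatter), so the wide gap from the 2,3-dichlorophenyl of compound 2 is not confined to hydroxyl-bearing aryl groups. The steps of no change at the digits printed from compound 3 to compound 4 (within the scatter) and a 1.5-fold higher number from compound 1 to compound 4 (0.17 log units; within the scatter) place the methoxy-bearing ring of compound 4 with the hydroxyl-bearing rings of compound 1 and compound 3, and the number of oxygen substituents does not separate these three compounds. No supporting measurement bears on why these results fall as they do.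

Open, from the compounds shown here alone, is whether a phenyl carrying a single chlorine stays with compound 2 or joins compound 1, compound 3 and compound 4. Also open, going by these compounds, is whether bromine or trifluoromethyl in place of the chlorines keeps the number of compound 2.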